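From compound 3 to compound 4 at the limit

This account rests on a few compounds, and the source may have more. Where it says the series, first, only, none or still open, it means among the compounds named here.

Values so far in a functional assay on HEK293 cells (Homo sapiens) for cytotoxicity (a higher number here means that more compound is tolerated, a lower number that less compound is tolerated), are these
- compound 1 `COc1ccc([C@H]2CC(=O)N(c3cccc(N(C)C)c3)C2)cc1OC1CCCC1` gives > 10000 nM (a limit)
- compound 2 `CCCCNc1cccc(N2C[C@@H](c3ccc(OC)c(OC4CCCC4)c3)CC2=O)c1` gives > 10000 nM (a limit)
- compound 3 `COc1ccc([C@H]2CC(=O)N(c3cccc(NS(=O)(=O)c4ccc(F)cc4)c3)C2)cc1OC1CCCC1` gives > 10000 nM (a limit)

Compound 3 stands at > 10000 nM in this assay and this is a limit, not a number. Within the data shown here, the whole series so far is summed up by the limit of > 10000 nM in this assay, at which 3 of the 3 values shown sit, and offers no number to work from. Compound 4 `COc1ccc([C@H]2CC(=O)N(c3cccc(NS(=O)(=O)c4cccc(C)c4)c3)C2)cc1OC1CCCC1` has 3-methylphenyl in place of 4-fluorophenyl on a sulfonyl sulfur and is otherwise unchanged. Among the measured compounds shown here, three measured steps bear on this change, namely a step that the two limits leave unreadable from compound 1 to compound 2 and a step that the two limits leave unreadable from compound 1 to compound 3 and a step that the two limits leave unreadable from compound 2 to compound 3 with no size to carry over. Compound 3 at > 10000 nM is only a limit, and on that ground no step beyond the scatter is expected in this assay in either direction. The expected size is a step that the limit leaves unreadable from compound 3 to compound 4 as estimated here. For compound 4 the estimated value is 15000 nM with an expected range from 8000 nM to 40000 nM and a report as a limit is the likelier outcome.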

Compound 4, half-maximal cytotoxic concentration: > 10000 nM
Compound 4: no number, only a limit; the forecaster's own chance of this, stated with the estimate: 90%; the middle value does not contradict the limit.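

In this assay compound 4 gives > 10000 nM, a limit and not a number. No step among compound 1, compound 2, compound 3 and compound 4 can be read: the limit of > 10000 nM in this assay, at which 4 of the 4 values shown sit.

The compounds shown leave open whether any of these changes alters the tolerated concentration in this assay, and by how much.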